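Permeability notes on the fused-core acid series

This account rests on a few compounds, and the source may have more. Where it says the series, first, only, none or still open, it means among the compounds named here.

Compound 2 `CCc1cc2oc(=O)n(CCC(=O)O)c2cc1Cl` carries an ethyl group on the shared core. In a physicochemical assay for permeability, using PAMPA (on this read-out lower numbers stand for lower permeability and higher numbers for higher permeability), compound 2 gives only a limit of the assay, < 10 nm/s. Compound 1 `COCCOc1cc2oc(=O)n(CCC(=O)O)c2cc1Cl` carries a 2-methoxyethoxy group at the same carbon. In this assay compound 1 also gives only a limit, < 3 nm/s. The step that the two limits leave unreadable from compound 1 to compound 2 therefore has no readable size; the two values sit at the limit of < 10 nm/s in this assay, at which 1 of the 2 values shown sits, and at the limit of < 3 nm/s in this assay, at which 1 of the 2 values shown sits. Among the measured compounds shown here, compound 2 thus stands at a limit in this assay, and the one further value shown is a limit as well.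

Compound 3 `C[C@@H](Oc1cc2oc(=O)n(CCC(=O)O)c2cc1Cl)c1ncco1` differs from compound 2 by a group of 8 heavy atoms (5 carbon, 1 nitrogen, 2 oxygen; one five-membered aromatic ring with 2 hetero atoms) in place of a group of 2 heavy atoms (2 carbon; no ring), on an aromatic carbon. For the measured compounds named here, the only measured step bears on the same carbon but gives no size, so no direction for this change can be taken from it. The expected step is a step that the limit leaves unreadable from compound 2 to compound 3, nothing beyond the scatter. Compound 3 is estimated at 3 nm/s, within 0.5 nm/s to 15 nm/s, most likely again reported as a limit.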

Compound 3, apparent permeability: < 3 nm/s
Compound 3 was reported as a limit; the forecaster's own chance of this, stated with the estimate: 80%; the middle value lies on the limit itself.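

Compound 3 gives only a limit in this assay (< 3 nm/s). With this result, the steps among compound 1, compound 2 and compound 3 cannot be read. The compounds shown leave open whether these three groups on the shared core differ at all in this assay (no numerical value is available).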